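Chain length and hepatocyte inhibition in a keto-diacid series

The source may hold more compounds than are shown below. What is called first, only, known or untested is meant among the compounds shown, and "the series" means these compounds.

Measured in a functional assay on cells (Hepatocyte, Rattus norvegicus) for inhibition; a higher number here means a weaker inhibitor, a lower number a stronger inhibitor:
compound 1 `CC(C)(CCCCC(=O)CCCCC(C)(C)C(=O)O)C(=O)O`: 3000 nM
compound 2 `CC(C)(CCCCCC(=O)CCCCCC(C)(C)C(=O)O)C(=O)O`: 3000 nM
compound 3 `CC(C)(CCCCCCC(=O)CCCCCCC(C)(C)C(=O)O)C(=O)O`: 9000 nM

Compound 2 stands level with compound 1 at the digits shown; together they give the lowest numbers of the three. Compound 3 gives a higher number, and that gap lies beyond the scatter.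

Compound 4 `CC(C)(CCCCCC(=O)CCCCC(C)(C)C(=O)O)C(=O)O` differs from compound 2 by 1-carboxy-1-methylethyl in place of 2-carboxy-2-methylpropyl on a saturated chain carbon, four bonds along the chain from a carbonyl carbon. The result is a chain in which one half matches compound 2 and the other half matches compound 1, and those two compounds give the same number in this assay. No step beyond the scatter is expected in this assay from compound 2 to compound 4, so no change at the digits printed from compound 2 to compound 4 (within the scatter) is the estimated step. For compound 4 the estimated value is 3000 nM, with a range from 1500 nM to 6000 nM.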

Compound 4, half-maximal inhibitory concentration: 3000 nM
Estimate against measurement, compound 4: no gap at the digits printed; the measured number falls inside the stated range.
By their numbers in this assay, from the lowest: compounds 1, 2 and 4 (each within the scatter of the next); then compound 3.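

In this assay the exchange on this saturated chain carbon, four bonds along the chain from a carbonyl carbon, gives no change at the digits printed from compound 2 to compound 4 (within the scatter) and the opposite exchange on the other arm gives no change at the digits printed from compound 1 to compound 4 (within the scatter). The two arms therefore need not match: an unequal pair, 1-carboxy-1-methylethyl with 2-carboxy-2-methylpropyl, reads the same as either equal pair. Nothing available explains this agreement. Still open, going by these compounds, is whether a single 3-carboxy-3-methylbutyl arm paired with 2-carboxy-2-methylpropyl reads with compound 2 or with compound 3. On these data alone, the effect of an amine in place of the carbonyl is also open.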